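Replacing the phenoxymethyl group of compound 3

This account rests on a few compounds, and the source may have more. Where it says the series, first, only, none or still open, it means among the compounds named here.

Values in an ADME assay on HepG2 2.2.15 cells (Homo sapiens) for cytotoxicity; on this read-out lower numbers stand for higher toxicity in this test and higher numbers for lower toxicity in this test:
Compound 1 `O=C(OCCc1c(-c2ccccc2Cl)c2cc(Cl)ccc2[nH]c1=O)c1ccccc1`: 43000 nM
Compound 2 `O=C(OCCc1c(-c2ccccc2Cl)c2cc(Cl)ccc2[nH]c1=O)c1ccc([N+](=O)[O-])cc1`: 1600000 nM
Compound 3 `O=C(COc1ccccc1)OCCc1c(-c2ccccc2Cl)c2cc(Cl)ccc2[nH]c1=O`: 81000 nM

Compound 3 stands close to compound 1 and far from compound 2, as a 20-fold lower number from compound 2 to compound 3 (1.30 log units; beyond the scatter) shows. Compound 4 `COc1cccc(/C=C/C(=O)OCCc2c(-c3ccccc3Cl)c3cc(Cl)ccc3[nH]c2=O)c1` keeps the shared core and changes one group: 2-(3-methoxyphenyl)ethenyl in place of phenoxymethyl on a carbonyl carbon. Here, 2-(3-methoxyphenyl)ethenyl takes the place of phenoxymethyl on a carbonyl carbon. Among the compounds with values here, the closest precedent is the exchange of phenyl for phenoxymethyl, which gave a 1.9-fold higher number from compound 1 to compound 3 (0.28 log units; within the scatter). The one large change among these groups came with nitro, at a 37-fold higher number from compound 1 to compound 2 (1.57 log units; beyond the scatter), and compound 4 carries no nitro. In this assay, no step beyond the scatter is therefore expected. The expected step is a 1.2-fold lower number from compound 3 to compound 4 (0.06 log units; within the scatter). Compound 4 is estimated at 70000 nM, with an expected range of 25000 nM to 250000 nM.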

Compound 4, half-maximal cytotoxic concentration: > 1300000 nM
Compound 4 was reported as a limit; the forecaster's own chance of this, stated with the estimate: 10%; middle value at least 18-fold (1.26 log units) from the limit.
By their numbers in this assay, from the lowest: compounds 1 and 3 (each within the scatter of the next); then compound 2.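

Before compound 4, only the nitro group of compound 2 had moved the number far at this carbonyl carbon in this assay. A group without nitro, 2-(3-methoxyphenyl)ethenyl, does so too, with an at least 16-fold higher number from compound 3 to compound 4 (1.20 log units; beyond the scatter) and with an at least 30-fold higher number from compound 1 to compound 4 (1.48 log units; beyond the scatter). The figure for compound 4 is a limit of the assay, not a number, and the step between compounds 2 and 4 cannot be read: the limit of > 1300000 nM in this assay, at which 1 of the 4 values shown sits.

The compounds shown do not separate the effect of the double bond from that of the methoxy group. On these data alone, how a group carrying an amine or a carboxylic acid would read in this place remains open.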